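Aryl ether variation on a triazole-linked sulfonamide aromatase series

The compounds below may be only part of what the source reports. "The series", "measured", "known", "first", "only" and "open" are said of these compounds alone.

Compound 1: `COc1cc2c(cc1OC)CN(S(=O)(=O)c1ccc(-n3cc(COc4ccccc4C(C)=O)nn3)cc1)CC2`, 12500 nM
Compound 2: `COc1cc2c(cc1OC)CN(S(=O)(=O)c1ccc(-n3cc(COc4ccccc4C)nn3)cc1)CC2`, 12500 nM

Both compounds were tested in an assay on isolated protein for inhibition of Aromatase (Homo sapiens), read by fluorescence, with a stated time of 10 min; a higher number here means a weaker inhibitor, a lower number a stronger inhibitor. Compound 1 gives 12500 nM, and compound 2 gives 12500 nM; the step of no change at the digits printed from compound 1 to compound 2 (within the scatter) shows no change within the scatter. Compound 2 therefore stands level with compound 1 at the digits shown.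

Compound 3, `COc1cc2c(cc1OC)CN(S(=O)(=O)c1ccc(-n3cc(COc4cc(C=O)ccc4OC)nn3)cc1)CC2`, carries the change (5-formyl-2-methoxyphenyl in place of 2-methylphenyl on an oxygen on a saturated carbon). Going by the values given here, no measured step covers this exact change; the only comparison available is the step of no change at the digits printed from compound 1 to compound 2 (within the scatter), in which swapping one small aryl substituent for another left this assay unmoved. On that basis, the step to compound 3 is expected to stay within the scatter: no change at the digits printed from compound 2 to compound 3 (within the scatter). Compound 3 is estimated at 12500 nM in this assay, with a range from 5000 nM to 30000 nM.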

Compound 3, half-maximal inhibitory concentration: 12500 nM
For compound 3 middle estimate and measured number coincide at the digits printed, within the range that was stated.
By their numbers in this assay, from the lowest: compounds 1, 2 and 3 (each within the scatter of the next).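

In this assay, putting 5-formyl-2-methoxyphenyl in place of 2-methylphenyl on the oxygen gives no change at the digits printed from compound 2 to compound 3 (within the scatter), and putting the same group in place of 2-acetylphenyl gives no change at the digits printed from compound 1 to compound 3 (within the scatter). The earlier pair had exchanged only one substituent on the aromatic ring, whereas here a group of 10 heavy atoms with 2 hydrogen-bond acceptors replaces one of 7 heavy atoms with none, and the reading at this position still holds. No available evidence accounts for this insensitivity.

The compounds shown leave open whether an amine or a carboxylic acid on this aromatic ring, or a longer chain in its place, would shift the number in this assay. They also leave open whether a change in the shared core would do so.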